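A few compounds are considered here, and "the series" means these few. Any claim that something is new, unique, unknown or untested is made for them only; others in the source may bear on it.

Three compounds sharing one core differ only in the carboxy-bearing group on a carbonyl carbon. In a functional assay on NCI-H441 cells (Homo sapiens) for antiproliferative activity, with a stated time of 24 h (a lower number here means a stronger inhibitor, a higher number a weaker inhibitor), compound 1 `O=C(O)/C=C/C(=O)N1C/C(=C\c2ccccc2F)C(=O)/C(=C/c2ccccc2F)C1` gives 29000 nM, compound 2 `O=C(O)CCCC(=O)N1C/C(=C\c2ccccc2F)C(=O)/C(=C/c2ccccc2F)C1` gives 60000 nM, and compound 3 `O=C1/C(=C/c2ccccc2F)CN(C(=O)C2CCCCC2C(=O)O)C/C1=C\c1ccccc1F` gives 55000 nM. Compound 3 cannot be separated from either of the others, as the data show a 1.1-fold lower number from compound 2 to compound 3 (0.04 log units; within the scatter) and a 1.9-fold higher number from compound 1 to compound 3 (0.28 log units; within the scatter). Going by the values given here, only one measured step clears the scatter, and it is modest: a 2.1-fold higher number from compound 1 to compound 2 (0.32 log units; beyond the scatter).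

Compound 4 `CC(=O)N1C/C(=C\c2ccccc2F)C(=O)/C(=C/c2ccccc2F)C1` comes next, and its change is far larger: methyl in place of 2-carboxycyclohexyl on a carbonyl carbon. In short, this places methyl in place of 2-carboxycyclohexyl on a carbonyl carbon, so the carboxy group is gone. All three measured steps swap one carboxy-bearing group for another, and none removes it. They therefore show how little the number moved among such groups, but not what losing the carboxy group does.

In this assay, a modest move to a lower number is expected, though this direction is a tentative judgment and the data do not establish it. The estimated step is a 2.5-fold lower number from compound 3 to compound 4 (0.40 log units; beyond the scatter). For compound 4, the estimated value is 22000 nM, with an expected range from 6000 nM to 70000 nM.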

Compound 4, half-maximal inhibitory concentration: 54000 nM
Compound 4: the middle estimate sits 2.5-fold (0.39 log units) below what was measured, and the stated range covers the measured number.
By their numbers in this assay, from the lowest: compounds 1, 4, 3 and 2 (each within the scatter of the next, the first and the last beyond it).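

In this assay the carboxy group itself can go: the acetyl compound shows a 1.0-fold lower number from compound 3 to compound 4 (0.01 log units; within the scatter) and a 1.1-fold lower number from compound 2 to compound 4 (0.05 log units; within the scatter) and also a 1.9-fold higher number from compound 1 to compound 4 (0.27 log units; within the scatter) with all three steps printed as within the scatter. The earlier compounds shown here only traded one carboxy-bearing group for another, whereas this result shows that cutting the large 2-carboxycyclohexyl group, ring included, down to a single methyl on this carbonyl carbon leaves the number inside the scatter of all three acids. Compound 4 thus joins a flat set in which the sole gap beyond the scatter remains the modest one separating compound 1 and compound 2, and no measurement shown offers an explanation for this flatness.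

All four compounds keep the rest of the shared core unchanged, so these numbers say nothing about how changes elsewhere on it would read in this assay. As far as these compounds go, it also remains open whether a different kind of group on this carbonyl carbon, such as an amine-bearing chain, a longer plain carbon chain or a benzene ring, would move the number beyond the scatter in either direction.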